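Replacing a Triazolyl-Phenyl Head with a Chloropyridyl Ring

The compounds below may be only part of what the source reports. "The series", "measured", "known", "first", "only" and "open" are said of these compounds alone.

Measured compounds:
compound 1, `CC1(OC(=O)N2CC3COCC(C2)C3Oc2ncnc(Oc3ccccc3F)c2F)CC1`, which gives 75 nM in a functional assay for agonist activity at Glucose-dependent insulinotropic receptor (Mus musculus), read by cAMP accumulation; a higher number here means that more compound is needed for the effect, a lower number that less compound is needed
compound 2, `CC1(OC(=O)N2CC3COCC(C2)C3Oc2ncnc(Nc3ccc(F)cc3F)c2F)CC1`, which gives 44 nM
compound 3, `CC1(OC(=O)N2CC3COCC(C2)C3Oc2ncnc(Nc3ccc(-n4cncn4)cc3F)c2F)CC1`, which gives 278 nM

Compound 3 gives the highest number of the three, so it needs the most compound for the effect; compound 1 and compound 2 both give lower numbers, and compound 3 stands beyond the scatter from each of them.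

Compound 4, `CC1(OC(=O)N2CC3COCC(C2)C3Oc2ncnc(Nc3cccnc3Cl)c2F)CC1`, is not yet measured. It differs from compound 3 in one place: a group of 7 heavy atoms (5 carbon, 1 nitrogen, 1 chlorine; one six-membered aromatic ring with 1 hetero atom) in place of a group of 12 heavy atoms (8 carbon, 3 nitrogen, 1 fluorine; one five-membered aromatic ring with 3 hetero atoms, one six-membered aromatic ring of carbon only), on a nitrogen on an aromatic ring. For the measured compounds named here, two measured steps bear on this. The step of a 6.3-fold higher number from compound 2 to compound 3 (0.80 log units; beyond the scatter) shows that attaching the 1H-1,2,4-triazol-1-yl to the aryl head raised the number modestly; compound 4 removes that group again and carries a single small aromatic ring instead. The step of a 1.7-fold lower number from compound 1 to compound 2 (0.23 log units; within the scatter) shows that swapping one small aryl head for another stayed within the scatter. Taken together, a drop back toward the range of compound 2 is expected, so a modest decrease beyond the scatter is expected as a 4.6-fold lower number from compound 3 to compound 4 (0.67 log units; beyond the scatter). Compound 4 is therefore estimated at 60 nM, within a range from 20 nM to 180 nM.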

Compound 4, half-maximal effective concentration: 58 nM
Estimate against measurement, compound 4: 1.0-fold (0.01 log units) above; low and high end bracket the measured number.
By their numbers in this assay, from the lowest: compounds 2, 4 and 1 (each within the scatter of the next); then compound 3.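

In this assay, putting 2-chloropyridin-3-yl on the nitrogen in place of the triazole-bearing head gives a clear change (a step of a 4.8-fold lower number from compound 3 to compound 4 (0.68 log units; beyond the scatter)), so the higher number of compound 3 does not carry over to every new head at this position. Until now, every head at this position had an aromatic ring of carbon only, and compound 4 shows that a ring with a nitrogen in it and a chlorine on it can serve here as well: the step to it from the 2,4-difluorophenyl head is small (a step of a 1.3-fold higher number from compound 2 to compound 4 (0.12 log units; within the scatter)). The comparison with the 2-fluorophenoxy head, with its oxygen link, also gives no real difference (a step of a 1.3-fold lower number from compound 1 to compound 4 (0.11 log units; within the scatter)), so among these four compounds only compound 3 stands apart.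

No measured property of these groups is available to explain what sets compound 3 apart. On these data alone, it also remains open how the ring nitrogen and the chlorine each contribute, which a plain pyridin-3-yl or a 2-chlorophenyl head would help separate, and how a morpholine ring on the head would compare with the triazole.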